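Removing one trifluoromethyl from a bis-trifluoromethyl aryl urea

The compounds below may be only part of what the source reports. "The series", "measured", "known", "first", "only" and "open" are said of these compounds alone.

Of the compounds shown here, three sharing one core have been tested in a functional assay on 786-0 cells (Homo sapiens) for inhibition, read by sulforhodamine B assay, with a stated time of 48 h, tested at 100 uM; on this read-out lower numbers stand for a stronger effect and higher numbers for a weaker effect at the one concentration tested. Compound 1 `O=C(Nc1cccc(-n2cc(-c3ccncc3)c(-c3cc(O)cc(Cl)c3)n2)c1)Nc1ccc(Cl)c(C(F)(F)F)c1` gives -50%, and compound 2 `O=C(Nc1cccc(-n2cc(-c3ccncc3)c(-c3cc(O)cc(Cl)c3)n2)c1)Nc1ccc(Cl)c(Cl)c1` gives -58%. Compound 3 `COc1cc(Cl)cc(-c2nn(-c3cccc(NC(=O)Nc4cc(C(F)(F)F)cc(C(F)(F)F)c4)c3)cc2-c2ccncc2)c1` gives -70%, the lowest of the three numbers and therefore the strongest effect seen so far: it stands beyond the scatter from compound 2 and further still from compound 1.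

Compound 4 `COc1cc(Cl)cc(-c2nn(-c3cccc(NC(=O)Nc4cccc(C(F)(F)F)c4)c3)cc2-c2ccncc2)c1` differs from compound 3 in one place: hydrogen in place of trifluoromethyl on an aromatic carbon. The site is on an aromatic carbon of a six-membered aromatic ring of carbon only, meta to a trifluoromethyl group.

Among the compounds with values here, the only measured step that touches the same part of the molecule is the change from trifluoromethyl to chloro, a number 8 percentage points lower from compound 1 to compound 2 (within the scatter). Within the data shown here, no measured step removes a group outright, so the size of the change is uncertain. Since chloro in place of trifluoromethyl did little, only a modest weakening toward higher numbers is expected from compound 3 to compound 4, estimated as a number 15 percentage points higher from compound 3 to compound 4 (beyond the scatter). Compound 4 is therefore expected to give about -55%, within a range from -75% to -35%.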

Compound 4, a percentage reported as activity, at one concentration (the size of the read-out at that concentration, not a potency): -57%
Beside the measured number, compound 4's estimate is 2 percentage points above it; measured number inside the range.
By their numbers in this assay, from the lowest: compound 3; then compounds 2, 4 and 1 (each within the scatter of the next).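

In this assay, hydrogen in place of trifluoromethyl gives a number 13 percentage points higher from compound 3 to compound 4 (beyond the scatter), the first step shown that lies beyond the scatter and the first that removes a group outright rather than swapping it for another. The step is modest and compound 4 still gives -57%, so the effect at this one concentration does not rest on this trifluoromethyl alone. Nothing available explains why this change shifts the read-out.

On these data alone, it remains open how other groups on this aromatic carbon, such as an amine or a carboxylic acid, would compare with trifluoromethyl and hydrogen. As far as these compounds go, it is also open whether the same removal would give a step of similar size on the core of compound 1, which carries a hydroxyl where compound 3 carries a methoxy.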